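The compounds below may be only part of what the source reports. "The series", "measured", "known", "first", "only" and "open" are said of these compounds alone.

Going by the values given here, in a functional assay on the whole organism with Cavia porcellus as the target (on this read-out lower numbers stand for an effect already at smaller amounts and higher numbers for an effect only at larger amounts of compound), compound 2 `CCCn1cc(Cc2ccc(C(=O)NS(=O)(=O)c3ccccc3C)cc2OC)c2cc(C(=O)NCC3CCCC3)ccc21` gives 4.8 umol/kg, the only actual number so far. Compound 1 `COc1cc(C(=O)NS(=O)(=O)c2ccccc2C)ccc1Cc1cn(C)c2ccc(C(=O)NCC(C)C)cc12` reports only a limit, > 30 umol/kg. Compound 3 `CCCn1cc(Cc2ccc(C(=O)NS(=O)(=O)c3ccccc3C)cc2OC)c2cc(C(=O)NCC(C)C)ccc21`, still to be measured, differs from compound 2 in one place: isopropyl in place of cyclopentyl on a saturated chain carbon bound to an amide-type nitrogen. This puts isopropyl in place of cyclopentyl on a saturated chain carbon bound to an amide-type nitrogen; cut one bond further out, cyclopentylmethyl gives way to isobutyl. Among the compounds with values here, no measured pair isolates this change, so the expectation rests on compound 2 at 4.8 umol/kg as the sole numerical anchor. A modest move towards a larger dose is expected, though a result within the usual scatter would not be surprising. The expected size is a 1.7-fold higher number from compound 2 to compound 3 (0.22 log units; within the scatter). Compound 3 is estimated at 8 umol/kg, with an expected range of 3 umol/kg to 25 umol/kg.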

Compound 3, dose for half-maximal effect: 31 umol/kg
Compound 3: middle estimate off by 3.9-fold (0.59 log units), on the low side; measured number outside the range, above it.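

In this assay the group on the amide nitrogen now has a measured step of its own: isopropyl in place of cyclopentyl on a saturated chain carbon bound to an amide-type nitrogen gives a 6.5-fold higher number from compound 2 to compound 3 (0.81 log units; beyond the scatter). Cyclopentylmethyl and isobutyl are therefore not interchangeable at this position in the core of compound 2, and of these two groups cyclopentylmethyl gives the effect at the smaller dose. Compound 1 carries only a limit, not a number, so its step to compound 3 cannot be read: the limit of > 30 umol/kg in this assay, at which 1 of the 3 values shown sits.

Still open, on these data alone, is whether a cyclohexyl ring or a longer chain such as n-pentyl in this place would give a lower number than compound 2 or a higher one. Also open, as far as these compounds go, is how an amine or a carboxylic acid on this chain would read out.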